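The source may report more compounds than this note shows. Statements on the series, on what has been measured and on what is new or still open speak of the compounds shown alone.

Measured compounds:
- Compound 1 `Cc1nn(-c2nc(-c3ccc(Cl)c(Cl)c3)c(SC(C)C)s2)c(C(=O)O)c1-c1cccc(F)c1`: in a functional assay on BJAB cells (Homo sapiens) for antiproliferative activity, with a stated time of 4 days (on this read-out higher numbers stand for an effect only at larger amounts of compound and lower numbers for an effect already at smaller amounts), compound 1 gives 900 nM
- Compound 2 `Cc1nn(-c2nc(-c3ccc(Cl)c(Cl)c3)c(SC(C)C)s2)c(C(=O)O)c1-c1ccncc1`: in this assay compound 2 gives 5900 nM

Compound 1 stands at the lowest of the two numbers in this assay; its nearest neighbour is compound 2, reached by a 6.6-fold higher number from compound 1 to compound 2 (0.82 log units; beyond the scatter), a step beyond the scatter.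

The step to compound 3 `Cc1nn(-c2nc(-c3ccc(Cl)c(Cl)c3)c(SC(C)C)s2)c(C(=O)O)c1-c1cccnc1` alters the same position of the shared core of compound 1: pyridin-3-yl in place of 3-fluorophenyl on an aromatic carbon. For the measured compounds named here, only one measured step bears on it, the one from compound 1 to compound 2, in which a pyridin-4-yl replaced the 3-fluorophenyl, and that gave a 6.6-fold higher number from compound 1 to compound 2 (0.82 log units; beyond the scatter). The pyridin-3-yl of compound 3 is a different ring from the pyridin-4-yl of compound 2, so the measured step is a guide rather than a template, but it is the only one available. Because of a 6.6-fold higher number from compound 1 to compound 2 (0.82 log units; beyond the scatter) a higher number is expected in this assay for compound 3, though its size is uncertain.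

For compound 3 the estimate is 3000 nM, with a range of 1000 nM to 9000 nM, corresponding to an expected 3.3-fold higher number from compound 1 to compound 3 (0.52 log units; beyond the scatter).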

Compound 3, half-maximal effective concentration: 12000 nM
Compound 3: middle estimate off by 4.0-fold (0.60 log units), on the low side; measured number outside the range, above it.
By their numbers in this assay, from the lowest: compound 1; then compound 2; then compound 3.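

In this assay, the pyridin-3-yl costs more than the pyridin-4-yl did, with a 13-fold higher number from compound 1 to compound 3 (1.12 log units; beyond the scatter), so both pyridine rings at this place give higher numbers than the 3-fluorophenyl, and none of the three compounds goes against this. The two pyridine rings also differ from each other, with a 2.0-fold higher number from compound 2 to compound 3 (0.31 log units; beyond the scatter), a modest step but one beyond the scatter, so the number at this place depends on where the ring nitrogen sits in the entering group and not only on its presence. Nothing available gives a reason for this order.

The compounds shown leave open how much of the step from the 3-fluorophenyl comes from losing the fluorine and how much from gaining the ring nitrogen, a question that an unsubstituted phenyl at this place would help to separate. They also leave open whether a pyridin-2-yl would continue the order seen for the two pyridine rings, and whether a methoxy group or an amine on the ring would bring the number back towards that of compound 1.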